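The source may hold more compounds than are shown below. What is called first, only, known or untested is meant among the compounds shown, and "the series" means these compounds.

In a functional assay on MKN-28 cells (Homo sapiens) for cytotoxicity, read by MTT assay (on this read-out higher numbers stand for weaker inhibition and lower numbers for stronger inhibition), compound 1 `C=C1C(=O)[C@]23C[C@@]1(Cl)CC[C@H]2[C@@]12C=CC(=O)[C@](C)(C(=O)O1)[C@H]2[C@@H]3C(=O)OC` gives 4800 nM and compound 2 `C=C1C(=O)[C@]23C[C@@]1(Cl)CC[C@H]2[C@@]12C=CC(=O)[C@](C)(C(=O)O1)[C@H]2[C@@H]3C(=O)OCc1ccccc1` gives 6800 nM, so the two stand within the scatter of each other. Compound 3 `C=C1C(=O)[C@]23C[C@@]1(OCC)CC[C@H]2[C@@]12C=CC(=O)[C@](C)(C(=O)O1)[C@H]2[C@@H]3C(=O)OC` carries one change from compound 1: ethoxy in place of chloro on a saturated ring carbon. Going by the values given here, the only measured step, a 1.4-fold higher number from compound 1 to compound 2 (0.15 log units; within the scatter), put phenyl in place of hydrogen on a saturated chain carbon, not on this ring carbon, so it offers only weak guidance. No step beyond the scatter is expected, and no direction is favoured: the estimated change is a 1.0-fold higher number from compound 1 to compound 3 (0.02 log units; within the scatter). Compound 3 is estimated at 5000 nM, with an expected range of 1800 nM to 14000 nM.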

Compound 3, half-maximal inhibitory concentration: 82700 nM
Compound 3: middle estimate off by 17-fold (1.22 log units), on the low side; measured number above the stated range.
By their numbers in this assay, from the lowest: compounds 1 and 2 (each within the scatter of the next); then compound 3.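

In this assay, ethoxy in place of chloro on this saturated ring carbon gives a 17-fold higher number from compound 1 to compound 3 (1.24 log units; beyond the scatter), the first step beyond the scatter among these compounds. The group on this ring carbon can therefore strongly shift the measured cytotoxicity, and swapping chloro for ethoxy here weakens inhibition. Nothing available here accounts for the size of this step. As far as these compounds go, whether the loss of chloro or the arrival of ethoxy matters more remains open. So does how a hydroxyl group, a fluoro group, an amine or a longer chain on this carbon would fare.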